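Expected Loss of Potency From Compound 3 to Compound 4

The compounds below may be only part of what the source reports. "The series", "measured", "known", "first", "only" and "open" are said of these compounds alone.

Compound 3 `Cc1nc(C)c(-c2nn(-c3ccc(F)cc3)cc2C2CC(c3cc(Br)ccc3O)=NN2)s1` was tested in an ADME assay on PANC-1 cells (Homo sapiens) for inhibition, read by MTT assay (on this read-out higher numbers stand for weaker inhibition of growth and lower numbers for stronger inhibition of growth), where compound 3 gives 76.4 ug/mL. Of the two plain numbers this is the highest. Compound 1 `Cc1ccc(O)c(C(=O)/C=C/c2cn(-c3ccc(F)cc3)nc2-c2sc(C)nc2C)c1` gives 52.4 ug/mL in this assay, a value within the scatter of the number for compound 3. Compound 2 `Cc1nc(C)c(-c2nn(-c3ccc(F)cc3)cc2/C=C/C(=O)c2cc(Cl)c(C)cc2O)s1` reaches only the assay limit of > 250 ug/mL in this assay. Compound 4 `Cc1nc(C)c(-c2nn(-c3ccc(F)cc3)cc2C2CC(c3cc(Cl)c(C)cc3O)=NN2)s1` differs from compound 3 by 5-chloro-2-hydroxy-4-methylphenyl in place of 5-bromo-2-hydroxyphenyl on a carbon with a double bond to nitrogen. Among the measured compounds shown here, the one measured step with the same entering group is an at least 4.7-fold higher number from compound 1 to compound 2 (0.67 log units; beyond the scatter), which ran into the limit given by the limit of > 250 ug/mL in this assay, at which 1 of the 3 values shown sits. A weakening of similar size is expected here, about a 2.9-fold higher number from compound 3 to compound 4 (0.46 log units; beyond the scatter). Compound 4 is therefore estimated at 220 ug/mL, in a range from 90 ug/mL to 600 ug/mL.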

Compound 4, concentration for 50% growth inhibition: 127 ug/mL
Compound 4: the middle estimate sits 1.7-fold (0.24 log units) above what was measured, within the range that was stated.
By their numbers in this assay, from the lowest: compounds 1, 3 and 4 (each within the scatter of the next, the first and the last beyond it). At a limit, above all of these: compound 2.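

In this assay, the swap at this place gives a 1.7-fold higher number from compound 3 to compound 4 (0.22 log units; within the scatter) and so stays within the scatter: on this five-membered non-aromatic ring with 2 nitrogen, 5-chloro-2-hydroxy-4-methylphenyl costs no clear activity against 5-bromo-2-hydroxyphenyl. On a carbonyl carbon, the same entering group gave an at least 4.7-fold higher number from compound 1 to compound 2 (0.67 log units; beyond the scatter) and ended at a limit of the assay, not a number: the limit of > 250 ug/mL in this assay, at which 1 of the 4 values shown sits.

Going by these compounds, the chlorine and the methyl arrive together here, so their separate contributions stay unknown. On these data alone, how an amine or a carboxylic acid on this phenyl ring would read also remains open.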